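Chlorine moved on the benzylsulfanyl arm: one step, repeated

This account rests on a few compounds, and the source may have more. Where it says the series, first, only, none or still open, it means among the compounds named here.

Measured compounds:
compound 1, `COc1ccc(C2N=C(SCc3ccccc3Cl)NC(C)=C2C(=O)Nc2ccc(Br)cc2)cc1`, gives 13.3% in a functional assay on the whole organism (artery, strain albino) with Rattus norvegicus as the target, with a stated time of 600 min, at a dose of 10 mg/kg by the oral route; on this read-out higher numbers stand for more inhibition at the one dose given (going by the name of the read-out) and lower numbers for less inhibition
compound 2, `COc1ccc(C2N=C(SCc3cccc(Cl)c3)NC(C)=C2C(=O)Nc2ccc(Br)cc2)cc1`, gives 32.8%
compound 3, `CC1=C(C(=O)Nc2ccc([N+](=O)[O-])cc2)C(c2ccc(Br)cc2)N=C(SCc2ccccc2Cl)N1`, gives 9.7%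

Going by the values given here, the account begins with the one change that is seen twice. Compound 2 differs from compound 1 by 3-chlorophenyl in place of 2-chlorophenyl on a saturated chain carbon bound to a sulfur. In this assay this change produced a number 19.5 percentage points higher from compound 1 to compound 2 (beyond the scatter). Compound 3 differs from compound 1 in more than one place, so the difference between the two cores is not broken down here; compound 3 stands lowest of the three, within the scatter of compound 1 and beyond it from compound 2. Compound 4, `CC1=C(C(=O)Nc2ccc([N+](=O)[O-])cc2)C(c2ccc(Br)cc2)N=C(SCc2cccc(Cl)c2)N1`, is not yet measured and differs from compound 3 by 3-chlorophenyl in place of 2-chlorophenyl on a saturated chain carbon bound to a sulfur, the same change at the same place. From compound 3 to compound 4 the writer expects a step of a number 17.3 percentage points higher from compound 3 to compound 4 (beyond the scatter), because the same change gave a number 19.5 percentage points higher from compound 1 to compound 2 (beyond the scatter) and compound 3 starts from 9.7%. Compound 4 is therefore expected to give 27%, estimated between 10% and 45%.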

Compound 4, a percentage reported as inhibition, in the whole organism at one dose (the size of the read-out at that dose, not a potency): 5.1%
Estimate against measurement, compound 4: 21.9 percentage points above; measured number outside the range, below it.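

In this assay, 3-chlorophenyl in place of 2-chlorophenyl gave a number 4.6 percentage points lower from compound 3 to compound 4 (within the scatter), so the rise seen on the other core did not reappear. The two steps differ by more than repeated measurement would account for: the same change on two cores in this assay, a number 19.5 percentage points higher (beyond the scatter) from compound 1 to compound 2 and a number 4.6 percentage points lower (within the scatter) from compound 3 to compound 4, 24.1 percentage points apart, beyond the scatter of two such steps. This shows that, in this series, a step read on one core could not be carried over to the other; it does not show which feature of the cores is responsible, since compound 1 and compound 3 differ in more than one place.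

The compounds shown leave open how the step would read with a fluorine or a methyl group in place of the chlorine. They also leave open how it would read on a core bearing an amine in place of the nitro group.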